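Ketone-bearing oxazole series against diacylglycerol lipase-alpha

A few compounds are considered here, and "the series" means these few. Any claim that something is new, unique, unknown or untested is made for them only; others in the source may bear on it.

Three measured compounds share a phenylalkyl ketone attached to a five-membered aromatic core, and all were tested in an assay on HEK-293T cells for inhibition of diacylglycerol lipase-alpha (Homo sapiens), read by colorimetric assay; on this read-out lower numbers stand for stronger inhibition and higher numbers for weaker inhibition. Compound 1 `O=C(CCCCCc1ccccc1)c1nc2cc([N+](=O)[O-])ccc2o1` gives 891 nM in this assay. Compound 2 `CC(=O)c1coc(C(=O)CCCCCCc2ccccc2)n1` gives 123 nM. Compound 3 `COc1cnc(C(=O)CCCCCCc2ccccc2)o1` returns only a limit of the assay, > 10000 nM, so no number is available for it; (the limit of > 10000 nM in this assay, at which 1 of the 3 values shown sits).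

Among the two numbers shown, compound 2 stands lowest, and the gap to compound 1 lies beyond the usual scatter of this assay. Going by the values given here, no pair of compounds that differ in a single place has been measured, so the effect of a single change on this core is not yet known from direct comparison.

Compound 4 `O=C(CCCCCCc1ccccc1)c1nc(-c2ccccn2)co1` is the next compound, not yet measured in this assay. It differs from compound 2 in one place: pyridin-2-yl in place of acetyl on an aromatic carbon. Without a measured step of this kind, the expectation rests only on compound 2 at 123 nM as the starting point. The expected step from compound 2 to compound 4 is modest and toward a lower number, a 2.1-fold lower number from compound 2 to compound 4 (0.31 log units; beyond the scatter), though a result within the scatter is also plausible. For compound 4 the estimate in this assay is 60 nM, with a likely range from 15 nM to 300 nM.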

Compound 4, half-maximal inhibitory concentration: > 10000 nM
Compound 4: only a limit was reported; the forecaster's own chance of this, stated with the estimate: 5%; at least 160-fold (2.22 log units) between middle value and limit.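

Going by these compounds alone, the swap of acetyl for pyridin-2-yl gives the first single-place comparison on this core, and the change is large: an at least 81-fold higher number from compound 2 to compound 4 (1.91 log units; beyond the scatter). Compound 4 gives > 10000 nM, which is a limit and not a number, and the series now has a second compound at that limit: the limit of > 10000 nM in this assay, at which 2 of the 4 values shown sit. The aromatic carbon next to the ring nitrogen is therefore a position where the substituent matters strongly, and with the phenylalkyl ketone chain unchanged, the one hydrogen-bond acceptor counted in both acetyl and pyridin-2-yl is not enough to keep compound 4 near compound 2.

Going by these compounds, it remains open whether the carbonyl of acetyl is what matters at this position, a question that a methyl ester, a primary amide or a carboxylic acid there could address. A phenyl or a pyridin-3-yl at the same carbon would show whether any six-membered aromatic ring gives the same outcome as pyridin-2-yl, or whether that outcome belongs to this ring alone.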